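The source may hold more compounds than are shown below. What is called first, only, known or untested is meant among the compounds shown, and "the series" means these compounds.

Working notes on the series.

Three compounds of the series have been run in an assay on isolated protein for displacement of a labelled ligand from 5-hydroxytryptamine receptor 6 (Homo sapiens), read by scintillation counting, with a stated time of 1 h; on this read-out lower numbers stand for stronger inhibition and higher numbers for weaker inhibition. Compound 1 `COc1ccc2c(ccn2S(=O)(=O)c2ccccc2)c1` gives 127 nM and stands at the lowest number of the three, though compound 2 `O=S(=O)(c1ccccc1)n1ccc2c(N3CCCCC3)cccc21`, which gives 128 nM, sits within the usual scatter of it, so the two cannot be placed in order. Compound 3 `CN(C)c1cccc2c1ccn2S(=O)(=O)N1CCCCC1` gives 39100 nM, a number far beyond the scatter from both, and it differs from compound 1 at more than one place, so no single change can be held to account for that gap.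

Compound 4 `CC(=O)N1CCN(c2ccc3c(ccn3S(=O)(=O)c3ccccc3)c2)CC1` is the next member and has not yet been run in this assay. Against compound 1 the difference is 4-acetylpiperazin-1-yl in place of methoxy on an aromatic carbon. For the measured compounds named here, no step between two measured compounds isolates a change of this kind at this position, so there is no direct precedent to lean on. The expectation is that the step from compound 1 to compound 4 stays modest, a 1.2-fold higher number from compound 1 to compound 4 (0.07 log units; within the scatter), with no direction that can be called beyond the scatter. On that basis compound 4 is estimated at 150 nM in this assay, within a range from 30 nM to 800 nM, the width reflecting how little the shown compounds constrain this change.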

Compound 4, inhibition constant: 4850 nM
Compound 4: the middle estimate sits 32-fold (1.51 log units) below what was measured; measured number outside the range, above it.
By their numbers in this assay, from the lowest: compounds 1 and 2 (each within the scatter of the next); then compound 4; then compound 3.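

In this assay, for the compounds shown here, the aromatic carbon that carries methoxy in compound 1 proves sensitive to what stands on it: 4-acetylpiperazin-1-yl in place of methoxy gives a 38-fold higher number from compound 1 to compound 4 (1.58 log units; beyond the scatter), the first single-place change that can be read. The entering group has 9 heavy atoms against 2, and it brings a six-membered non-aromatic ring with 2 hetero atoms and a double bond outside aromatic rings, so this one step changes all of these together and cannot separate them. No measurement to hand accounts for the step.

The compounds shown leave open which part of 4-acetylpiperazin-1-yl goes with the higher number: a piperazine with a free ring amine, a morpholine or a plain dimethylamino group at the same carbon would begin to separate the acetyl, the ring and the size of the group. They also leave open whether groups only a little larger than methoxy, such as ethoxy or a short alkoxy chain ending in a hydroxyl, hold the number near that of compound 1 or already move it upward.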